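Octyloxy to benzyloxy on the shared core

A few compounds are considered here, and "the series" means these few. Any claim that something is new, unique, unknown or untested is made for them only; others in the source may bear on it.

In a functional assay on brain (Rattus norvegicus, strain Wistar) for inhibition (on this read-out higher numbers stand for weaker inhibition and lower numbers for stronger inhibition), compound 1 `Cc1[nH]c(=O)n(C2CCCCC2)c1-c1ccc(CC(C)C)cc1` gives 10900 nM and compound 2 `CCCCCCCCOc1ccc(-c2c(C)[nH]c(=O)n2C2CCCCC2)cc1` gives 8500 nM in the same read-out. These two numbers sit within the scatter of each other, so compound 2 holds no separate rank.

Compound 3 `Cc1[nH]c(=O)n(C2CCCCC2)c1-c1ccc(OCc2ccccc2)cc1` is not yet measured. It carries benzyloxy where compound 2 carries octyloxy, with phenyl in place of heptyl on a saturated chain carbon bound to an oxygen on an aromatic ring as the counted difference: phenyl in place of heptyl on a saturated chain carbon bound to an oxygen on an aromatic ring.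

Among the compounds with values here, one measured step bears on this place, namely a 1.3-fold lower number from compound 1 to compound 2 (0.11 log units; within the scatter) for octyloxy in place of isobutyl on an aromatic carbon. Neither measured compound has a ring in this group, so the data do not test that feature directly. Within the data shown here, with only that small step as a guide, no step beyond the scatter is expected in this assay here. The expected move is a 1.1-fold higher number from compound 2 to compound 3 (0.02 log units; within the scatter) by estimate and carries wide uncertainty. For compound 3 the estimate is 9000 nM with an expected range of 3500 nM to 22000 nM in this read-out.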

Compound 3, half-maximal inhibitory concentration: 8300 nM
Beside the measured number, compound 3's estimate is 1.1-fold (0.04 log units) above it; measured number inside the range.
By their numbers in this assay, from the lowest: compounds 3, 2 and 1 (each within the scatter of the next).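

In this assay, the step from octyloxy to benzyloxy is a 1.0-fold lower number from compound 2 to compound 3 (0.01 log units; within the scatter). Within the data shown here, this is the first test of a ring in this group, and phenyl in place of heptyl on a saturated chain carbon bound to an oxygen on an aromatic ring produces no step beyond the scatter, although the ring replaces an open chain. Measured against isobutyl, benzyloxy gives a 1.3-fold lower number from compound 1 to compound 3 (0.12 log units; within the scatter), so isobutyl, octyloxy and benzyloxy hold no separate rank in this read-out, and no evidence at hand explains this flat response.

Open is whether any group at this place can move the number beyond the scatter, since the three shown here are all carbon-based groups without a hydrogen-bond donor or acceptor beyond the ether oxygen of the two alkoxy-type groups. A carboxylic acid or an amine at the end of the chain, a small methoxy group, or a fluorine or hydroxyl on the phenyl ring of benzyloxy would each put that question to the series.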